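The source may hold more compounds than are shown below. What is called first, only, known or untested is meant among the compounds shown, and "the series" means these compounds.

Measured so far in an ADME assay on Vero cells (Chlorocebus sabaeus) for cytotoxicity, read by resazurin assay, with a stated time of 3 days; a higher number here means a weaker inhibitor, a lower number a stronger inhibitor:
- compound 1 `CCCCNC(=O)Nc1cc2nc(C3CCCCC3)[nH]c2cc1N(CC)CC`: > 100 ug/mL
- compound 2 `C=Cc1cccc(C(=O)Nc2cc3nc(C4CCCCC4)[nH]c3cc2N(CC)CC)c1`: > 100 ug/mL
- compound 3 `CCCNC(=O)Nc1cc2nc(C3CCCCC3)[nH]c2cc1N(CC)CC`: > 100 ug/mL

Each of these values is a limit of the assay rather than a number. Compound 1 reaches only the limit > 100 ug/mL in this assay. Compound 2 likewise reaches only the limit > 100 ug/mL. Compound 3 also reaches only the limit > 100 ug/mL, and so its standing is known only as this limit, as described in the limit of > 100 ug/mL in this assay, at which 3 of the 3 values shown sit. Compound 4 `CCN(CC)c1cc2[nH]c(C3CCCCC3)nc2cc1NC(=O)c1ccc(F)cc1F` differs from compound 3 by 2,4-difluorophenyl in place of propylamino on a carbonyl carbon. The closest measured step is a step that the two limits leave unreadable from compound 2 to compound 3, whose size the two limits leave unreadable, and a step that the two limits leave unreadable from compound 1 to compound 3 is unreadable as well. Compound 2 carries an aromatic ring on the carbonyl carbon and still sits at the limit, so compound 4 is expected to remain at the limit too, with an estimated step that the limit leaves unreadable from compound 3 to compound 4. Compound 4 is therefore estimated at 150 ug/mL, within 50 ug/mL to 400 ug/mL.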

Compound 4, half-maximal inhibitory concentration: > 100 ug/mL
Compound 4: only a limit was reported; the forecaster's own chance of this, stated with the estimate: 85%; the middle value does not contradict the limit.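

Compound 4 also gives only a limit, so its steps from compound 1, compound 2 and compound 3 cannot be read: the limit of > 100 ug/mL in this assay, at which 4 of the 4 values shown sit. The compounds shown leave open at what concentration any of them would reach half-maximal inhibition in this assay.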